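Working notes: the step from compound 3 to compound 4

A few compounds are considered here, and "the series" means these few. Any claim that something is new, unique, unknown or untested is made for them only; others in the source may bear on it.

Measured so far:
compound 1 `CN(C)Cc1cc2c(N)nc(-c3ccco3)nc2s1` gives "not determined" (no result reported) as its entry
compound 2 `Nc1nc(-c2ccco2)nc2sc(CNC3CCCCC3)cc12` gives "not determined" (no result reported) as its entry
compound 3 `Nc1nc(-c2ccco2)nc2sc(CN3CC=CCC3)cc12` gives < 3 mg/kg as a limit

The read-out for this series is a functional assay on the whole organism (strain balb/c) with Mus musculus as the target, with a stated time of 30 min (on this read-out higher numbers stand for an effect only at larger amounts of compound and lower numbers for an effect already at smaller amounts), and only compound 3 has a result there. In this assay compound 3 stands at < 3 mg/kg as a limit and not a number. Compound 1 and compound 2 have no result, so the series holds no single number. The evidence amounts to the limit of < 3 mg/kg in this assay, at which 1 of the 3 values shown sits, and nothing more.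

Compound 4 `Nc1nc(-c2ccco2)nc2sc(CN3CCC(F)CC3)cc12` is still to be measured in this assay and differs from compound 3 by a group of 7 heavy atoms (5 carbon, 1 nitrogen, 1 fluorine; one six-membered non-aromatic ring with 1 hetero atom) in place of a group of 6 heavy atoms (5 carbon, 1 nitrogen; one six-membered non-aromatic ring with 1 hetero atom), on a saturated chain carbon bound to an aromatic carbon in the structure. The group that enters is 4-fluoropiperidin-1-yl, on a saturated chain carbon bound to an aromatic carbon. Going by the values given here, the series offers no measured step of this kind, so no step beyond the usual scatter is expected in this assay in either direction. The only anchor for that expectation is compound 3 with its limit of < 3 mg/kg in the assay. The estimated size is a step that the limit leaves unreadable from compound 3 to compound 4 and it remains an expectation. Compound 4 is expected at 2 mg/kg with an estimated range from 0.6 mg/kg to 6 mg/kg in this assay once measured.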

Compound 4, dose for half-maximal effect: < 1 mg/kg
Compound 4: only a limit was reported; the forecaster's own chance of this, stated with the estimate: 40%; middle value at least 2.0-fold (0.30 log units) away from the limit.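

Going by these compounds alone, the entries for compound 3 and compound 4 in this assay are both limits and not numbers, so no step between them can be read. The compounds shown leave open whether 4-fluoropiperidin-1-yl, in place of the group in compound 3, shifts this read-out in either direction, and by how much.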